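The source may hold more compounds than are shown below. What is called first, only, known or untested is meant among the compounds shown, and "the series" means these compounds.

Values in a functional assay on the whole organism with Scenedesmus acutus as the target, with a stated time of 20 h (on this read-out lower numbers stand for stronger inhibition and higher numbers for weaker inhibition), so far
- compound 1 `O=C(O)c1cc(N2C(=O)C3=C(CCCC3)C2=O)c(F)cc1Cl` gives 3160 nM
- compound 2 `COC(=O)c1cc(N2C(=O)C3=C(CCCC3)C2=O)c(F)cc1Cl` gives 170 nM
- compound 3 `CCOC(=O)c1cc(N2C(=O)C3=C(CCCC3)C2=O)c(F)cc1Cl` is not yet measured

Compound 2, at 170 nM in this assay, holds the lower of the two numbers. The next change is methyl in place of hydrogen on a saturated chain carbon bound to an oxygen next to a carbonyl group in the side chain, which reads as methoxycarbonyl to ethoxycarbonyl: methyl in place of hydrogen on a saturated chain carbon bound to an oxygen next to a carbonyl group.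

Among the measured compounds shown here, only one measured step bears on this, and only loosely. It is a 19-fold lower number from compound 1 to compound 2 (1.27 log units; beyond the scatter) for methyl in place of hydrogen on an oxygen next to a carbonyl group. That step is large, but it acts on the oxygen itself and not on a chain carbon, so its size does not carry over. For the measured compounds named here, no measured step lengthens this chain. The expected move is therefore none beyond the scatter, with no direction favoured, and the estimated step is no change at the digits printed from compound 2 to compound 3 (within the scatter) in this read-out. For compound 3 the estimated value is 170 nM with an expected range from 60 nM to 480 nM in this assay.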

Compound 3, half-maximal inhibitory concentration: 87.1 nM
For compound 3 the middle estimate is 2.0-fold (0.29 log units) above the measured one, and the stated range covers the measured number.
By their numbers in this assay, from the lowest: compounds 3 and 2 (each within the scatter of the next); then compound 1.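

In this assay the change from methoxycarbonyl to ethoxycarbonyl, methyl in place of hydrogen on a saturated chain carbon bound to an oxygen next to a carbonyl group, gives a 2.0-fold lower number from compound 2 to compound 3 (0.29 log units; within the scatter) and so leaves the two esters indistinguishable on this read-out. The earlier compounds shown here showed only that a methyl on the oxygen matters; the large step to the ethyl ester, a 36-fold lower number from compound 1 to compound 3 (1.56 log units; beyond the scatter), now shows that this difference from the carboxylic acid of compound 1 persists when the chain carries one more carbon. The notes hold no independent measurement that could account for either step.

Still open, as far as these compounds go, is whether a longer chain such as propyl or butyl, a branched isopropyl or an amide in place of the ester stays within the same range in this assay or moves beyond the scatter. Also open, from the compounds shown here alone, is whether the same ranking of carboxylic acid and esters would hold on a different core, since all three compounds share the core of compound 1.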